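Chloro added to the core of compound 3

The source may report more compounds than this note shows. Statements on the series, on what has been measured and on what is new or still open speak of the compounds shown alone.

In a functional assay on CAKI-1 cells (Homo sapiens) for cytotoxicity, read by sulforhodamine B assay, with a stated time of 48 h (on this read-out lower numbers stand for stronger inhibition of growth and higher numbers for weaker inhibition of growth), three compounds with a shared bicyclic core have been measured. Compound 1 `ClCc1cccc(Cn2cnc3ncnc(Cl)c32)c1` gives 2130 nM. Compound 2 `ClCc1cccc(Cn2cnc3c(Cl)ncnc32)c1` gives 1540 nM. Compound 3 `ClCc1ccccc1Cn1cnc2ncnc(Cl)c21` gives 2340 nM. Compound 3 carries the highest of the three numbers, yet its value sits within the usual scatter of compound 1 and also of compound 2, so none of the three can be set apart from the others on this read-out; the three values only show that they lie close together.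

Compound 4 `ClCc1ccccc1Cn1cnc2nc(Cl)nc(Cl)c21` has not been measured in this assay. It differs from compound 3 in one place: chloro in place of hydrogen on an aromatic carbon. Among the measured compounds shown here, no pair of measured compounds shows what this kind of change does on this core, so the size and direction of the step from compound 3 to compound 4 are not known from the data at hand. It is therefore expected that the step of a 1.3-fold lower number from compound 3 to compound 4 (0.11 log units; within the scatter) stays within the scatter, with no clear movement in either direction. On that basis compound 4 is estimated to give about 1800 nM in this assay, with a range from 700 nM to 4500 nM.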

Compound 4, concentration for 50% growth inhibition: 19500 nM
Estimate against measurement, compound 4: 11-fold (1.03 log units) below; measured number outside the range, above it.
By their numbers in this assay, from the lowest: compounds 2, 1 and 3 (each within the scatter of the next); then compound 4.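

In this assay, among the compounds shown here, chloro in place of hydrogen on the aromatic carbon between two ring nitrogen atoms gives the first step in this set that lies beyond the scatter, with an 8.3-fold higher number from compound 3 to compound 4 (0.92 log units; beyond the scatter) as its size. The earlier compounds shown here could not be set apart on this read-out and offered no view of this position, whereas this step shows that the position is not indifferent to substitution and that chloro there goes with weaker inhibition of growth. Nothing in the data at hand accounts for this movement.

The compounds shown leave open whether the effect belongs to chloro itself or would also appear with another group on the same carbon, such as an amine, a methoxy group or a methyl group. For the compounds shown here, they also leave open whether the same change would move the number by a similar amount on the core of compound 1 or compound 2, since this single pair gives only one reading of the change, with one arrangement of the rest of the molecule.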